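Moving the methyl on the phenoxy group of a thiazolidinedione

The source may hold more compounds than are shown below. What is called first, only, known or untested is meant among the compounds shown, and "the series" means these compounds.

Measured compounds and their values in a functional assay for agonist activity at Free fatty acid receptor 1 (Homo sapiens), read by FLIPR, in the presence of a further agent that is not named here; on this read-out lower numbers stand for an effect already at smaller amounts and higher numbers for an effect only at larger amounts of compound:
compound 1, `O=C1NC(=O)C(Cc2ccc(Oc3ccccc3)cc2)S1`, gives 307 nM;
compound 2, `Cc1ccc(C)c(Oc2ccc(CC3SC(=O)NC3=O)cc2)c1`, gives 238 nM;
compound 3, `Cc1ccccc1Oc1ccc(CC2SC(=O)NC2=O)cc1`, gives 124 nM.

Compound 3 has the lowest number of the three. Its gap to compound 2 lies within the scatter, so the two cannot be ordered; its gap to compound 1 lies beyond it, shown by a 2.5-fold lower number from compound 1 to compound 3 (0.39 log units; beyond the scatter). The step of a 1.9-fold lower number from compound 2 to compound 3 (0.28 log units; within the scatter) is within the scatter.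

Compound 4, `Cc1ccc(Oc2ccc(CC3SC(=O)NC3=O)cc2)cc1`, has not yet been measured in this assay. It differs from compound 3 in that (4-methylphenyl in place of 2-methylphenyl on an oxygen on an aromatic ring). Among the measured compounds shown here, no measured step moves a methyl from one position of this ring to another; the two steps that bear on the change only tell that a methyl added to the bare ring lowered the number modestly and that a second methyl changed little. Compound 4 is therefore expected to fall between compound 1 and compound 3, with an estimated step of a 1.8-fold higher number from compound 3 to compound 4 (0.25 log units; within the scatter). For compound 4 the expected value is 220 nM, with a range from 90 nM to 550 nM.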

Compound 4, half-maximal effective concentration: 547 nM
For compound 4 the middle estimate is 2.5-fold (0.40 log units) below the measured one, and the stated range covers the measured number.
By their numbers in this assay, from the lowest: compounds 3, 2, 1 and 4 (each within the scatter of the next, the first and the last beyond it).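

In this assay, the exchange of 2-methylphenyl for 4-methylphenyl on the oxygen shows that the place of the methyl on this ring counts, even with the same atoms, with a 4.4-fold higher number from compound 3 to compound 4 (0.64 log units; beyond the scatter). The methyl of 4-methylphenyl does not set its compound apart from the bare ring, with a 1.8-fold higher number from compound 1 to compound 4 (0.25 log units; within the scatter), so the modest gain seen earlier holds for 2-methylphenyl and not for a methyl on this ring in general. Taking away a methyl other than that of 2-methylphenyl gave steps of like size on two cores: the same change on two cores in this assay, a 1.9-fold lower number (0.28 log units; within the scatter) from compound 2 to compound 3 and a 1.8-fold lower number (0.25 log units; within the scatter) from compound 4 to compound 1, 1.1-fold (0.03 log units) apart, within the scatter of two such steps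

From the compounds shown here alone, whether a methoxy group, a chlorine atom or a longer chain in place of the methyl of 2-methylphenyl would keep the number of compound 3 stays open. What lies behind the step between the two methylphenyl groups also stays open.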